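Second trifluoromethyl on the aryl of compound 1

A few compounds are considered here, and "the series" means these few. Any claim that something is new, unique, unknown or untested is made for them only; others in the source may bear on it.

Measured compounds:
compound 1 `O=C(Nc1cccc(-n2cc(-c3ccncc3)c(-c3ccc(Cl)c(O)c3)n2)c1)Nc1cccc(C(F)(F)F)c1` — 1440 nM
compound 2 `COc1cc(-c2nn(-c3cccc(NC(=O)c4cccc(C(F)(F)F)c4)c3)cc2-c2ccncc2)ccc1Cl` — 1400 nM
compound 3 `O=C(Nc1cccc(-n2cc(-c3ccncc3)c(-c3ccc(Cl)c(O)c3)n2)c1)Nc1ccc(Cl)c(Cl)c1` — 1410 nM

In a functional assay on K562 cells (Homo sapiens) for inhibition, read by sulforhodamine B assay, with a stated time of 48 h (a higher number here means a weaker inhibitor of growth, a lower number a stronger inhibitor of growth), compound 1 gives 1440 nM, the highest of the three numbers, yet compound 3 with 1410 nM and compound 2 with 1400 nM both sit within the scatter of it, so no order among them can be read.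

Compound 4 `O=C(Nc1cccc(-n2cc(-c3ccncc3)c(-c3ccc(Cl)c(O)c3)n2)c1)Nc1cc(C(F)(F)F)cc(C(F)(F)F)c1` differs from compound 1 by trifluoromethyl in place of hydrogen on an aromatic carbon. Among the measured compounds shown here, the one measured step at this ring, a 1.0-fold lower number from compound 1 to compound 3 (0.01 log units; within the scatter), exchanged the whole aryl group and stayed within the scatter; compound 2, no single-point change, also lies in the same band. No measured change at this position has moved the number, so no step beyond the scatter is expected in this assay .

Compound 4 is expected to give 1500 nM, within 700 nM to 3200 nM. The expected step is a 1.0-fold higher number from compound 1 to compound 4 (0.02 log units; within the scatter).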

Compound 4, concentration for 50% growth inhibition: 433 nM
The estimate for compound 4 lay 3.5-fold (0.54 log units) above the measured number; measured number below the stated range.
By their numbers in this assay, from the lowest: compound 4; then compounds 2, 3 and 1 (each within the scatter of the next).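

In this assay, among the compounds shown here, the step of a 3.3-fold lower number from compound 1 to compound 4 (0.52 log units; beyond the scatter) is the first change at this aryl to move the number beyond the scatter, whereas a 1.0-fold lower number from compound 1 to compound 3 (0.01 log units; within the scatter) stayed within it. This aryl is therefore not silent: a second trifluoromethyl, meta to a trifluoromethyl group, shifts the number where the 3,4-dichlorophenyl exchange did not. No data shown here bear on the reason for this step. Going by these compounds, whether the shift is specific to trifluoromethyl remains open, and a chlorine, a methoxy or an amine on the same aromatic carbon would test this.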